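The source may hold more compounds than are shown below. What is called first, only, known or untested is meant among the compounds shown, and "the series" means these compounds.

Compound 1 `CC(=O)OC[C@H]1O[C@@H](n2cc(CN3C(=O)/C(=C\c4ccc(C)cc4)c4ccccc43)nn2)[C@H](OC(C)=O)[C@@H](OC(C)=O)[C@@H]1OC(C)=O` is the reference point of this pair: in an ADME assay on NIH3T3 cells (Homo sapiens) for cytotoxicity, read by sulforhodamine B assay, with a stated time of 48 h (on this read-out lower numbers stand for stronger inhibition and higher numbers for weaker inhibition), compound 1 gives 9000 nM, the lowest of the two numbers recorded in the series. Among the compounds with values here, the only other measured member, compound 2 `CC(=O)OC[C@H]1O[C@@H](n2cc(CN3C(=O)/C(=C/c4cccs4)c4ccccc43)nn2)[C@H](OC(C)=O)[C@@H](OC(C)=O)[C@@H]1OC(C)=O`, gives 48100 nM in this assay, so its inhibition is weaker than that of compound 1 by a margin beyond the scatter. Within the data shown here, no pair of measured compounds differs in a single place, so no step can be quantified from the data themselves; the two values simply show that replacing the aromatic group on the double-bonded chain carbon can move the read-out by a substantial amount.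

Compound 3 `CC(=O)OC[C@H]1O[C@@H](n2cc(CN3C(=O)/C(=C\c4ccco4)c4ccccc43)nn2)[C@H](OC(C)=O)[C@@H](OC(C)=O)[C@@H]1OC(C)=O` differs from compound 1 by furan-2-yl in place of 4-methylphenyl on a double-bonded chain carbon bound to a double-bonded ring carbon. The expectation in this assay is a step toward weaker inhibition, of moderate size, given as a 2.8-fold higher number from compound 1 to compound 3 (0.44 log units; beyond the scatter), because compound 2 gives 48100 nM in this assay. On that basis the value expected for compound 3 in this assay is 25000 nM, with a range from 8000 nM to 70000 nM.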

Compound 3, half-maximal inhibitory concentration: 13300 nM
Estimate against measurement, compound 3: 1.9-fold (0.27 log units) above; measured number inside the range.
By their numbers in this assay, from the lowest: compounds 1 and 3 (each within the scatter of the next); then compound 2.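

In this assay, within the data shown here, the step at this position, on a double-bonded chain carbon bound to a double-bonded ring carbon, is a 1.5-fold higher number from compound 1 to compound 3 (0.17 log units; within the scatter), the first change that can be read in a single place. Furan-2-yl in place of 4-methylphenyl therefore gives two compounds that this read-out cannot tell apart, so exchanging a six-membered aromatic ring of carbon only for a five-membered aromatic ring with a hetero atom, with one hydrogen-bond acceptor entering, does not by itself separate them here. No measurement accompanies this step that could account for the two numbers lying so close.

The compounds shown leave open whether this place accepts only aromatic rings, or whether a saturated group such as cyclohexyl or a plain butyl chain would read the same way. Also open, going by these compounds, is whether a charged or amine-bearing group, for example a 4-carboxyphenyl or a 4-(dimethylamino)phenyl ring, would keep the number in this range or move it beyond the scatter.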